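A sulfonyl-side swap on compound 2

The compounds below may be only part of what the source reports. "The series", "measured", "known", "first", "only" and "open" are said of these compounds alone.

Compound 1 `CC(O)(CSc1cc(C(F)(F)F)cc(C(F)(F)F)c1)C(=O)Nc1ccc(C#N)cc1C(F)(F)F` gives 6650 nM
Compound 2 `CC(O)(CS(=O)(=O)c1cccc(C(F)(F)F)c1)C(=O)Nc1cc(C(F)(F)F)cc(C(F)(F)F)c1` gives 9980 nM

Only these two compounds have been measured so far. In a functional assay on VCaP cells (Homo sapiens) for antiproliferative activity, read by fluorescence and propidium iodide staining, with a stated time of 96 h (on this read-out higher numbers stand for weaker inhibition and lower numbers for stronger inhibition), compound 2 gives 9980 nM and compound 1 gives 6650 nM as its value, and these two numbers lie within the usual scatter of each other. On these numbers, then, compound 2 cannot be told apart from compound 1.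

The next compound is compound 3 `CC(O)(CS(=O)(=O)c1ccccc1OC(F)(F)F)C(=O)Nc1cc(C(F)(F)F)cc(C(F)(F)F)c1` and it keeps the rest of compound 2 unchanged. The change 2-(trifluoromethoxy)phenyl in place of 3-(trifluoromethyl)phenyl on a sulfonyl sulfur puts 2-(trifluoromethoxy)phenyl in place of 3-(trifluoromethyl)phenyl on a sulfonyl sulfur.

Going by the values given here, no pair of measured compounds shows what a swap of this kind does, so the data offer no direct guide to its size or direction. Among the compounds with values here, the only anchor is compound 2 at 9980 nM on this scale, and no change beyond the scatter is expected in this assay from this swap. The expected step of a 1.2-fold lower number from compound 2 to compound 3 (0.10 log units; within the scatter) is small, and its direction is uncertain. In this assay the expected value for compound 3 is 8000 nM within an estimated range from 3000 nM to 20000 nM on repeated measurement.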

Compound 3, half-maximal inhibitory concentration: 9950 nM
Compound 3: middle estimate off by 1.2-fold (0.09 log units), on the low side; measured number inside the range.
By their numbers in this assay, from the lowest: compounds 1, 3 and 2 (each within the scatter of the next).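

In this assay, putting 2-(trifluoromethoxy)phenyl in place of 3-(trifluoromethyl)phenyl on a sulfonyl sulfur gives a 1.0-fold lower number from compound 2 to compound 3 (0.00 log units; within the scatter), so compound 2 and compound 3 cannot be told apart. Going by these compounds alone, this is the first pair that differs in only one place, and it gives the first direct reading at this position: here, the entering group's extra oxygen and its one counted hydrogen-bond acceptor come with no difference this read-out can detect. No measurement at hand explains why the two compounds cannot be separated.

This single swap alters both the substituent and its place on the phenyl ring, so the compounds shown leave open what each of those two differences does on its own, and whether two opposing effects could be hidden in the result. They also leave open whether this position tolerates groups of a different kind, such as an unsubstituted phenyl, a ring bearing an amine or a carboxylic acid, or a longer alkyl chain on the sulfonyl sulfur.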